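Methoxy for Methylsulfonyl on a Bcl-2 Inhibitor Series

This account rests on a few compounds, and the source may have more. Where it says the series, first, only, none or still open, it means among the compounds named here.

Measured so far:
Compound 1 `Cc1c(C(=O)NCCCN2CCN(C)CC2)c(-c2cccc(N3CCN(c4ccc(NS(=O)(=O)c5cccc(S(C)(=O)=O)c5)cc4)CC3)c2)c(-c2ccc(Cl)cc2)n1C`: 2540 nM
Compound 2 `Cc1c(C(=O)O)c(-c2cccc(N3CCN(c4ccc(NS(=O)(=O)c5ccc(N[C@H](CCN6CC(O)C6)CSc6ccccc6)c(S(=O)(=O)C(F)(F)F)c5)cc4)CC3)c2)c(-c2ccc(Cl)cc2)n1C`: 7.7 nM
Compound 3 `CCn1c(C)c(C(=O)O)c(-c2cccc(N3CCN(c4ccc(NS(=O)(=O)c5ccc(N[C@H](CCN6CCC(O)CC6)CSc6ccccc6)c(S(=O)(=O)C(F)(F)F)c5)cc4)CC3)c2)c1-c1ccc(Cl)cc1`: 5.4 nM

Of the compounds shown here, three have been tested in an assay for inhibition of Apoptosis regulator Bcl-2 (Homo sapiens), read by fluorescence polarization, with a stated time of 2 h; a higher number here means a weaker inhibitor, a lower number a stronger inhibitor. Compound 1 stands at 2540 nM, the highest of the three numbers and therefore the weakest inhibitor of the set, since its gaps to both other compounds lie well beyond the usual scatter. Compound 2 gives 7.7 nM, and compound 3 gives 5.4 nM; these two lie within the scatter of each other, so no order between them can be claimed. Compounds 2 and 3 differ from compound 1 in several places at once, so the data do not show which of those changes carries the large gap.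

Compound 4 `COc1cccc(S(=O)(=O)Nc2ccc(N3CCN(c4cccc(-c5c(C(=O)NCCCN6CCN(C)CC6)c(C)n(C)c5-c5ccc(Cl)cc5)c4)CC3)cc2)c1` is compound 1 with a single change: methoxy in place of methylsulfonyl on an aromatic carbon. Among the compounds with values here, no measured pair in this set shows that same change on its own, so there is no step to lean on. A small change of this kind is expected to move the number little, if at all beyond the scatter, in either direction; the step from compound 1 to compound 4 in this assay is estimated at a 1.0-fold lower number from compound 1 to compound 4 (0.01 log units; within the scatter). Compound 4 is therefore expected to come out near 2500 nM, within a range of 900 nM to 7000 nM.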

Compound 4, half-maximal inhibitory concentration: 802 nM
Compound 4: middle estimate off by 3.1-fold (0.49 log units), on the high side; measured number below the stated range.
By their numbers in this assay, from the lowest: compounds 3 and 2 (each within the scatter of the next); then compound 4; then compound 1.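

In this assay, methoxy in place of methylsulfonyl on this aromatic carbon, meta to a large group, gives a 3.2-fold lower number from compound 1 to compound 4 (0.50 log units; beyond the scatter). Within the data shown here, this is the first single-place change in the set, and it shows that the group at this position can alter the number on its own, although the step is modest. It also shows that the methylsulfonyl group is not required for this level of inhibition, as the smaller methoxy group, with fewer heavy atoms and hydrogen-bond acceptors, goes with the lower number, though no measurement here explains the shift.

A single change cannot show how other groups at this position, such as a plain hydrogen, a chlorine or a nitrile, would compare with methoxy and methylsulfonyl. Going by these compounds, it also remains open whether the same swap would give a similar step on a compound that carries a carboxylic acid in place of the amide side chain of compound 1.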